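Three Thioureas and a Chain Swap at the Limit

The compounds below may be only part of what the source reports. "The series", "measured", "known", "first", "only" and "open" are said of these compounds alone.

Three thioureas sharing one core have been tested in a functional assay on HeLa cells (Homo sapiens) for cytotoxicity, read by MTT assay, with a stated time of 7 h; a lower number here means a stronger inhibitor, a higher number a weaker inhibitor. Compound 1 `S=C(Nc1ccnc2cc(Cl)ccc12)N1CCN(CC2CCCCC2)CC1` gives a value reported only as a limit of the assay, > 50000 nM. Compound 2 `S=C(Nc1ccnc2cc(Cl)ccc12)N1CCN(c2ccccc2)CC1` gives 43600 nM, and the step of an at least 1.1-fold lower number from compound 1 to compound 2 (0.05 log units; that floor lies within the scatter) lies within the scatter. Compound 3 `OCCNC(=S)Nc1ccnc2cc(Cl)ccc12` likewise gives only a limit, > 50000 nM. Its standing is thus known as a boundary, not a number, a boundary described by the limit of > 50000 nM in this assay, at which 2 of the 3 values shown sit. Compound 4 `CN(C)CCCNC(=S)Nc1ccnc2cc(Cl)ccc12` differs from compound 3 by (dimethylamino)methyl in place of hydroxy on a saturated chain carbon, two bonds along the chain from an amide-type nitrogen. Going by the values given here, no measured step covers this change, and the single step available lies within the scatter, so in this assay nothing beyond the scatter is expected and a limit remains the likeliest outcome. Compound 4 is estimated at 50000 nM, between 20000 nM and 150000 nM. The expected step is a number no higher from compound 3 to compound 4 (the limit leaves the size open).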

Compound 4, half-maximal inhibitory concentration: 48500 nM
Estimate against measurement, compound 4: 1.0-fold (0.01 log units) above; measured number inside the range.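

In this assay, the change at this chain position, from 2-hydroxyethyl to 3-(dimethylamino)propyl, gives a step of an at least 1.0-fold lower number from compound 3 to compound 4 (0.01 log units; that floor lies within the scatter). This extends the picture from the earlier step, made on an amine nitrogen in a ring, to the open chain, where a change of chain end and length also shows nothing beyond the scatter. The size of the step stays open, as one end of it is only a limit of the assay: the limit of > 50000 nM in this assay, at which 2 of the 4 values shown sit.

The compounds shown leave open whether any group on this chain moves the number beyond the scatter. A carboxylic acid, a primary amine or a longer chain could each test this.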